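Lysine diester of a fluorouracil nucleoside: removal of one ester

The compounds below may be only part of what the source reports. "The series", "measured", "known", "first", "only" and "open" are said of these compounds alone.

The series is followed in an ADME assay on a cell-free system (plasma, Homo sapiens) for metabolic stability; a lower number here means that the compound disappears faster, a higher number that the compound lasts longer. Compound 1 `NCCCC[C@H](N)C(=O)OC[C@H]1O[C@@H](n2cc(F)c(=O)[nH]c2=O)C[C@@H]1OC(=O)[C@@H](N)CCCCN` carries two (1,5-diaminopentyl)carbonyl groups and gives 0.492 h. Going by the values given here, of the three numbers so far this is the lowest; compound 2 `NCCCC[C@H](N)C(=O)OC[C@H]1O[C@@H](n2cc(F)c(=O)[nH]c2=O)C[C@@H]1O`, with 0.647 h, sits within the scatter of it, while compound 3 `C[C@H](NC(=O)[C@H](N)CCC(=O)OCc1ccccc1)C(=O)O`, at 2.63 h, lies beyond the scatter above it. Among the compounds with values here, no one-place step connects compound 3 to the others.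

Compound 4 `NCCCC[C@H](N)C(=O)O[C@H]1C[C@H](n2cc(F)c(=O)[nH]c2=O)O[C@@H]1CO` is the other mono-ester of the shared core. Relative to compound 1 the change is hydrogen in place of (1,5-diaminopentyl)carbonyl on an oxygen on a saturated carbon, the oxygen in question being the one on a saturated carbon whose other neighbour is a saturated chain carbon. Within the data shown here, the only step that bears on it is the removal of the same group from the other oxygen of the core, which gave a 1.3-fold higher number from compound 1 to compound 2 (0.12 log units; within the scatter). Loss of one (1,5-diaminopentyl)carbonyl from this core therefore has shown no movement beyond the scatter, and for compound 4 none is expected either, the step being estimated as a 1.2-fold higher number from compound 1 to compound 4 (0.09 log units; within the scatter). Compound 4 is accordingly expected at 0.6 h, with a range of 0.35 h to 1.1 h.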

Compound 4, half-life: 0.85 h
For compound 4 the middle estimate is 1.4-fold (0.15 log units) below the measured one; the measured number falls inside the stated range.
By their numbers in this assay, from the lowest: compounds 1, 2 and 4 (each within the scatter of the next); then compound 3.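

In this assay, hydrogen in place of (1,5-diaminopentyl)carbonyl on the oxygen on a saturated carbon whose other neighbour is a saturated chain carbon gives a 1.7-fold higher number from compound 1 to compound 4 (0.24 log units; within the scatter). Removal from the other oxygen of the core gives a 1.3-fold higher number from compound 1 to compound 2 (0.12 log units; within the scatter), so the loss of one group now stays within the scatter at either oxygen, and neither oxygen stands out on these numbers. Nothing available gives a cause for this result.

The compounds shown leave open what the core reads with hydrogen on both oxygens. They also leave open whether an acetyl group or a shorter chain carrying an amine, in place of (1,5-diaminopentyl)carbonyl on either oxygen, would move the number beyond the scatter.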